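The compounds below may be only part of what the source reports. "The series", "measured", "known", "first", "only" and "open" are said of these compounds alone.

Measured so far:
- compound 1 `CCc1cc(C(=O)N2CCCCc3ccccc32)ccc1CNC(=O)Nc1c(F)cccc1F`: 10 nM
- compound 2 `Cc1cc(C(=O)N2CCCCc3ccccc32)cc(C)c1CNC(=O)Nc1c(F)cccc1F`: 82 nM
- compound 3 `Cc1cc(C(=O)N2CCCCc3ccccc32)ccc1CNC(=O)Nc1ccccc1F`: 30 nM

The three measured compounds share one core and differ in the substitution of the aryl ring bearing the methylene urea and in the aryl group on the urea. In a functional assay on HEK293 cells for agonist activity at Vasopressin V2 receptor (Homo sapiens), read by a luciferase reporter and cAMP accumulation (a higher number here means that more compound is needed for the effect, a lower number that less compound is needed), compound 3 gives 30 nM, which places it second highest of the three numbers: compound 2 sits at a higher number and compound 1 at a lower one, and both of those gaps lie beyond the usual scatter.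

Compound 4 `Cc1cc(C(=O)N2CCCCc3ccccc32)ccc1CNC(=O)NCC(=O)O` keeps everything of compound 3 except the group on the far urea nitrogen: carboxymethyl in place of 2-fluorophenyl on an amide-type nitrogen. Within the data shown here, no measured pair here shows what happens when the aryl group on the urea is exchanged for an open chain of this kind, so the size of the step has to be guessed rather than read off. With the aromatic ring gone and an acid in its place, the step of a 100-fold higher number from compound 3 to compound 4 (2.00 log units; beyond the scatter) is expected to be large and towards a higher number, well beyond the scatter, with a real chance that this assay reports only a limit. Compound 4 is therefore estimated at 3000 nM, with a plausible range from 400 nM to 30000 nM.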

Compound 4, half-maximal effective concentration: 180 nM
Beside the measured number, compound 4's estimate is 17-fold (1.22 log units) above it; measured number outside the range, below it.
By their numbers in this assay, from the lowest: compound 1; then compound 3; then compound 2; then compound 4.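

In this assay, carboxymethyl in place of 2-fluorophenyl on an amide-type nitrogen gives a 6.0-fold higher number from compound 3 to compound 4 (0.78 log units; beyond the scatter), a step beyond the scatter but modest in size. Among these compounds, this is the first view of this position, and it shows that an aromatic ring on the far urea nitrogen is not needed for a measurable response: compound 4, whose new group has no ring, still gives a true number of 180 nM and not a limit. Nothing among the data given explains why the step is of this size.

This single exchange removes the 2-fluorophenyl ring and brings in a carboxylic acid at once, so the compounds shown cannot separate the two changes; a plain ethyl group, or the methyl ester of the same chain, would be needed to tell them apart. Also open, from the compounds shown here alone, is how a longer chain such as carboxyethyl, or an amine at the end of the chain, would compare with compound 4 in this assay.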